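Swapping thiophen-3-yl for pyridin-3-yl on compound 1

The compounds below may be only part of what the source reports. "The series", "measured", "known", "first", "only" and "open" are said of these compounds alone.

Among the compounds with values here, in a functional assay on MCF7 cells (Homo sapiens) for inhibition, with a stated time of 96 h (a higher number here means a weaker inhibitor, a lower number a stronger inhibitor), compound 1 (`COc1cc(C(=O)c2cn(-c3cccc(C)c3)cc2-c2ccsc2)cc(OC)c1OC`) gives 65 nM, the higher of the two numbers measured so far. Compound 2 (`COc1cc(C(=O)c2cn(-c3ccc(F)cc3)cc2-c2ccsc2)cc(OC)c1OC`), with 4-fluorophenyl in place of 3-methylphenyl on an aromatic nitrogen, gives 15 nM.

Compound 3 (`COc1cc(C(=O)c2cn(-c3cccc(C)c3)cc2-c2cccnc2)cc(OC)c1OC`) keeps the 3-methylphenyl group of compound 1 and changes elsewhere: pyridin-3-yl in place of thiophen-3-yl on an aromatic carbon. In short, pyridin-3-yl stands in place of thiophen-3-yl on an aromatic carbon. Within the data shown here, no measured step touches this place. Among the measured compounds shown here, the only step available, a 4.3-fold lower number from compound 1 to compound 2 (0.64 log units; beyond the scatter), concerns the other group, so it offers a sense of scale and no direction. A small rise in the number is therefore expected, though this rests on little evidence. The expected change is a 1.5-fold higher number from compound 1 to compound 3 (0.19 log units; within the scatter). For compound 3 the estimated value in this assay is 100 nM, with an expected range from 25 nM to 400 nM.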

Compound 3, half-maximal inhibitory concentration: 52 nM
Estimate against measurement, compound 3: 1.9-fold (0.28 log units) above; the range from low to high includes it.
By their numbers in this assay, from the lowest: compound 2; then compounds 3 and 1 (each within the scatter of the next).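

In this assay, replacing thiophen-3-yl with pyridin-3-yl gives a step that stays inside the scatter (a 1.3-fold lower number from compound 1 to compound 3 (0.10 log units; within the scatter)), so compound 1 and compound 3 cannot be told apart. Within the data shown here, this is the first reading at this aromatic carbon, and it shows that, with the 3-methylphenyl group held constant, a six-membered aromatic ring can stand in for the five-membered one without a separation in the numbers. No measurement at hand offers an explanation for this result.

As far as these compounds go, it remains open whether the same swap would read alike alongside the 4-fluorophenyl group of compound 2. The compounds shown also leave open how this position would respond to a group of a different kind, such as an amine, a carboxylic acid or a longer chain.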